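Swapping a thiophene for a phenyl on the ketone

The source may hold more compounds than are shown below. What is called first, only, known or untested is meant among the compounds shown, and "the series" means these compounds.

Of the compounds shown here, three sharing one core have been tested in a functional assay on MT4 cells (Homo sapiens) for antiproliferative activity, read by MTT assay, with a stated time of 96 h; on this read-out lower numbers stand for an effect already at smaller amounts and higher numbers for an effect only at larger amounts of compound. Compound 1 `COC(=O)/C(=C\c1c(-c2ccccc2)[nH]c2ccccc12)S(=O)(=O)c1ccccc1` gives 1000 nM, compound 2 `N#C/C(=C\c1c(-c2ccccc2)[nH]c2ccccc12)C(=O)c1cccs1` gives 400 nM, and compound 3 `O=C(/C(=C\c1c(-c2ccccc2)[nH]c2ccccc12)C(=O)C(F)(F)F)c1ccco1` gives 800 nM. Compound 2 thus has the smallest number of the three; its gap to compound 1 lies beyond the usual scatter, whereas its gap to compound 3 lies within it, so compound 2 and compound 3 cannot be told apart on this read-out.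

Compound 4 `N#C/C(=C\c1c(-c2ccccc2)[nH]c2ccccc12)C(=O)c1ccccc1` is the next candidate. It differs from compound 2 in one place only: phenyl in place of thiophen-2-yl on a carbonyl carbon. Both groups are flat aromatic rings bound to the carbonyl carbon, and the rest of the molecule, including the nitrile, is unchanged.

For the measured compounds named here, no pair of measured compounds shows this particular change, so its effect is unknown here. Given how close compound 2 and compound 3 sit despite differing in the same region, the expectation is a step of a 1.3-fold higher number from compound 2 to compound 4 (0.10 log units; within the scatter), with no direction that would exceed the scatter. Compound 4 is therefore estimated at 500 nM, in the range 200 nM to 1500 nM in this assay.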

Compound 4, half-maximal effective concentration: 500 nM
Beside the measured number, compound 4's estimate shows no gap at the digits printed; the measured number falls inside the stated range.
By their numbers in this assay, from the lowest: compounds 2, 4, 3 and 1 (each within the scatter of the next, the first and the last beyond it).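

Replacing thiophen-2-yl with phenyl on a carbonyl carbon gives a 1.3-fold higher number from compound 2 to compound 4 (0.10 log units; within the scatter) in this assay, so compound 2 and compound 4 cannot be told apart on this read-out. For the compounds shown here, this is the first pair here that differs in one place only, and it shows that, at this position, a five-membered aromatic ring with one hetero atom and a six-membered aromatic ring of carbon only give values within the usual scatter of each other. Nothing available explains this result.

On these data alone, both compounds carry an aromatic ring at this position, so it remains open whether the value would hold with a non-aromatic group there, such as a cyclohexyl ring or a butyl chain. As far as these compounds go, the effect of adding a methoxy group or a chlorine atom to the phenyl ring of compound 4 also remains open.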